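A few compounds are considered here, and "the series" means these few. Any claim that something is new, unique, unknown or untested is made for them only; others in the source may bear on it.

Within the data shown here, compound 2 `CN(C)C1(Cc2ccccc2)CCN(c2cc(C(F)(F)F)ccc2CNC(=O)Nc2cccc3cnccc23)CC1` is one of two compounds measured in an assay on CHO cells for antagonist activity at transient receptor potential cation channel subfamily V member 1 (Homo sapiens), read by scintillation counting, with a stated time of 5 min, in the presence of a further agent that is not named here (on this read-out higher numbers stand for an effect only at larger amounts of compound and lower numbers for an effect already at smaller amounts), the other being compound 1 `CN(C)C1(Cc2ccccc2)CCN(c2cc(C(F)(F)F)ccc2CNC(=O)Nc2cccc3ccncc23)CC1`. In this assay compound 1 gives 18.7 nM, and in this assay compound 2 gives 8.8 nM, so compound 2 stands at the lower of the two numbers. Among the measured compounds shown here, the single step between them, a 2.1-fold lower number from compound 1 to compound 2 (0.33 log units; beyond the scatter), moves the ring nitrogen within the same two-ring group on the amide-type nitrogen of the urea.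

Compound 3 `CN(C)C1(Cc2ccccc2)CCN(c2cc(C(F)(F)F)ccc2CNC(=O)Nc2cccc3ncccc23)CC1` carries the same atoms as compound 2, joined differently: quinolin-5-yl in place of isoquinolin-5-yl on an amide-type nitrogen. For the measured compounds named here, only one measured step bears on this change, a 2.1-fold lower number from compound 1 to compound 2 (0.33 log units; beyond the scatter), which shows that shifting the nitrogen within this two-ring group is worth a modest step. That step went toward a lower number, but nothing measured here says which way a further shift will go. The expectation is therefore a small step in this assay, close to the scatter, as a 1.4-fold higher number from compound 2 to compound 3 (0.13 log units; within the scatter). Compound 3 is estimated to give 12 nM, within a range from 4 nM to 40 nM.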

Compound 3, half-maximal effective concentration: 32 nM
Compound 3: the middle estimate sits 2.7-fold (0.43 log units) below what was measured, within the range that was stated.
By their numbers in this assay, from the lowest: compound 2; then compounds 1 and 3 (each within the scatter of the next).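

Compound 2 and compound 3 hold the same atoms and differ only in where the ring nitrogen sits, yet this assay shows a 3.6-fold higher number from compound 2 to compound 3 (0.56 log units; beyond the scatter), so this placement alone can carry a step beyond the scatter. Among these compounds, with this result, isoquinolin-5-yl is the one group of the three whose compound stands clear of both others on this amide-type nitrogen, since the earlier 2.1-fold lower number from compound 1 to compound 2 (0.33 log units; beyond the scatter) is also beyond the scatter. In contrast, the remaining pair shows a 1.7-fold higher number from compound 1 to compound 3 (0.23 log units; within the scatter), so quinolin-5-yl and isoquinolin-8-yl cannot be told apart here, and no outside measurement is available to explain why the nitrogen's placement matters.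

All three groups keep a single ring nitrogen, which leaves open how naphthalen-1-yl, with carbon only in both rings, would compare with isoquinolin-5-yl at this place. Also open, on these data alone, is whether adding an amino or methoxy group to isoquinolin-5-yl would move the number, and whether the same order of the three groups would hold on a different core.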